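A few compounds are considered here, and "the series" means these few. Any claim that something is new, unique, unknown or untested is made for them only; others in the source may bear on it.

Among the compounds with values here, compound 1 `CC(C)c1onc(-c2c(Cl)cccc2Cl)c1COc1ccc(-c2nc3ccc(C(=O)O)cc3n2-c2ccc(F)cc2)cc1` is the only member of this small set for which a number is available: in an assay on isolated protein for agonist activity at Bile acid receptor (Homo sapiens), read by TR-FRET (on this read-out higher numbers stand for an effect only at larger amounts of compound and lower numbers for an effect already at smaller amounts), compound 1 gives 15.1 nM. Compound 2 `CC(C)c1onc(-c2c(Cl)cccc2Cl)c1COc1ccc(-c2nc3ccc(C(=O)O)cc3n2C2CCCCC2)cc1` shares the same core but carries a cyclohexyl group on the aromatic nitrogen; in this assay compound 2 gives "not determined" (no result reported), so nothing can be said about how it compares with compound 1.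

Compound 3 `CC(C)c1onc(-c2c(Cl)cccc2Cl)c1COc1ccc(-c2nc3ccc(C(=O)O)cc3n2CC2CCCCC2)cc1` is the next variation. It differs from compound 1 in one place: cyclohexylmethyl in place of 4-fluorophenyl on an aromatic nitrogen. The flat fluorinated ring is thus exchanged for a saturated ring joined through a single carbon, at the same ring nitrogen.

Without any measured step between two compounds in this set, no rate of change can be read off. Swapping an aromatic ring for a non-aromatic one at this position is expected to cost some activity, probably a shift beyond the usual scatter, so the step of a 3.0-fold higher number from compound 1 to compound 3 (0.47 log units; beyond the scatter) is estimated to run toward weaker binding. Compound 3 is therefore expected to give about 45 nM in this assay, with a plausible range from 12 nM to 180 nM.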

Compound 3, half-maximal effective concentration: 19.9 nM
Compound 3: middle estimate off by 2.3-fold (0.35 log units), on the high side; low and high end bracket the measured number.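

Exchanging 4-fluorophenyl for cyclohexylmethyl on this aromatic nitrogen gives a 1.3-fold higher number from compound 1 to compound 3 (0.12 log units; within the scatter) in this assay and so leaves the two compounds indistinguishable on this read-out. For this one pair, then, an aromatic ring at this nitrogen is not needed to keep the reading where it is: a non-aromatic ring joined through a single carbon, with no fluorine on it, serves equally well. Why the two groups read alike cannot be said, as no independent data bear on this result.

On these data alone, with no result reported for compound 2, steps involving it cannot be read, and it stays open whether a cyclohexyl ring placed directly on the nitrogen, without the single carbon of cyclohexylmethyl, would match the reading of compound 3. Also open is how far this tolerance extends, for instance to a small methyl group, a longer alkyl chain or a chain ending in an amine, none of which appears among the compounds shown.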